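Substituent changes on the shared core: cytotoxicity notes

A few compounds are considered here, and "the series" means these few. Any claim that something is new, unique, unknown or untested is made for them only; others in the source may bear on it.

Compound 1 `CCCCCCCCOc1nc(N)nc2c1ncn2/C=C1/CC1(CO)CO`: in an ADME assay on MOLT-3 cells (Homo sapiens) for cytotoxicity, with a stated time of 7 days (a higher number here means that more compound is tolerated, a lower number that less compound is tolerated), compound 1 gives > 20000 nM, a limit of the assay.
Compound 2 `Nc1nc(NCc2ccccc2)c2ncn(/C=C3/CC3(CO)CO)c2n1`: in this assay compound 2 gives > 20000 nM, a limit of the assay.
Compound 3 `CCCCCCSc1nc(N)nc2c1ncn2/C=C1/CC1(CO)CO`: in this assay compound 3 gives > 20000 nM, a limit of the assay.

Compound 2 stands where the other two values stand, at the limit described in the limit of > 20000 nM in this assay, at which 3 of the 3 values shown sit, so no order among the three compounds can be read. The change from compound 2 to compound 4 `CCCCSc1nc(N)nc2c1ncn2/C=C1/CC1(CO)CO` is butylsulfanyl in place of benzylamino on an aromatic carbon. The measured steps that bear on this change are a step that the two limits leave unreadable from compound 2 to compound 3, a step that the two limits leave unreadable from compound 1 to compound 3 and a step that the two limits leave unreadable from compound 1 to compound 2, and the limits leave each of them without a readable size or direction. Among the measured compounds shown here, no measured step therefore sets an expected size or direction for the change in this assay. Compound 4 is expected to remain at the limit as well, which corresponds to an expected step that the limit leaves unreadable from compound 2 to compound 4. The estimate for compound 4 is 30000 nM, with a range from 15000 nM to 60000 nM.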

Compound 4, half-maximal cytotoxic concentration: > 20000 nM
Compound 4: only a limit was reported (the forecaster's own chance of this, stated with the estimate: 85%); the middle value lies beyond the limit too.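

No new step can be read between compound 4 and compound 1, compound 2 or compound 3, since all four stand at a limit of the assay: the limit of > 20000 nM in this assay, at which 4 of the 4 values shown sit.

The compounds shown leave open how far each tolerated concentration lies beyond that limit, and whether these substituents separate at all in this assay.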